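Ring Size at the Amide Nitrogen and Cell Growth Inhibition

The source may report more compounds than this note shows. Statements on the series, on what has been measured and on what is new or still open speak of the compounds shown alone.

Three compounds of this series have values in an ADME assay on MRC5 cells (Homo sapiens) for inhibition, with a stated time of 72 h; on this read-out lower numbers stand for an effect already at smaller amounts and higher numbers for an effect only at larger amounts of compound. Compound 1 `CO[C@H]1CC[C@H](NC(=O)c2n[nH]cc2NC(=O)c2ncoc2-c2ccccc2)CC1` gives 28000 nM in this assay. Compound 3 `CO[C@H]1CC[C@H](NC(=O)c2n[nH]cc2NC(=O)c2cnc3ccccn23)CC1` gives 5900 nM in this assay. For compound 2 `COc1cccc(OC)c1C(=O)Nc1c[nH]nc1C(=O)NC1CC1` the read-out in this assay is not a number but a limit, > 50000 nM. Going by the values given here, compound 2 therefore stands at the limit of > 50000 nM in this assay, at which 1 of the 3 values shown sits, the one value of the three that is a limit rather than a measured number.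

Compound 4 `COc1cccc(OC)c1C(=O)Nc1c[nH]nc1C(=O)NC1CCCCC1` has not yet been measured. It differs from compound 2 in one place: cyclohexyl in place of cyclopropyl on an amide-type nitrogen. Among the compounds with values here, no measured pair in this set shares that kind of change, so no step for it can be read from the data, and what the larger ring does to the read-out has to be guessed from the position of compound 2 alone. The expected step is an at least 1.4-fold lower number from compound 2 to compound 4 (0.15 log units; that floor lies within the scatter) in this assay, a move that is estimated to stay close to where compound 2 sits, with a real chance that the assay once more reports only a limit. Compound 4 is thus estimated at 35000 nM in this assay, within a range from 10000 nM to 80000 nM.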

Compound 4, half-maximal effective concentration: 35000 nM
The estimate for compound 4 equals the measured number at the digits printed; the measured number falls inside the stated range.
By their numbers in this assay, from the lowest: compound 3; then compounds 1 and 4 (each within the scatter of the next). At a limit, above all of these: compound 2.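

Going by these compounds alone, putting cyclohexyl in place of cyclopropyl on the amide-type nitrogen gives the first step that can be read in this set, in this assay, with an at least 1.4-fold lower number from compound 2 to compound 4 (0.15 log units; that floor lies within the scatter). Compound 2 forms one end of this step and its read-out is a limit, so the step gives only a floor and not a full size: the limit of > 50000 nM in this assay, at which 1 of the 4 values shown sits.

Since that floor lies within the scatter, the data do not establish a real effect of the change, although compound 4 does show that the cyclohexyl analogue gives a measured number rather than a limit.

How the read-out depends on ring size remains open, as the two rings shown leave cyclobutyl and cyclopentyl on the same nitrogen untested in this comparison. Whether a ring is needed at all is also unresolved, and an open hexyl chain or a tetrahydropyranyl ring, which carries a ring oxygen, in the same place would help to separate the presence of a ring from the number of carbons it brings.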